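The source may hold more compounds than are shown below. What is called first, only, known or untested is meant among the compounds shown, and "the series" means these compounds.

In a functional assay on cells (Splenocyte, Mus musculus, strain BALB/c) for inhibition, read by scintillation counting and thymidine incorporation, with stated times of 48 h and 8 h (on this read-out lower numbers stand for stronger inhibition and higher numbers for weaker inhibition), compound 1 `COc1ccccc1-c1nc(Cc2c[nH]c3ccccc23)no1` gives 16700 nM, and compound 2 `COc1cccc(-c2nc(Cc3c[nH]c4ccccc34)no2)c1` gives 18500 nM; the difference between the two cores is not broken down here, and the two values lie within the usual scatter of each other. Compound 3 `COc1ccc(-c2nc(Cc3c[nH]c4ccccc34)no2)c(OC)c1` arises from compound 1 by methoxy in place of hydrogen on an aromatic carbon, a change that brought a 1.9-fold lower number from compound 1 to compound 3 (0.29 log units; within the scatter), and in this assay compound 3 gives 8600 nM. Compound 4 `COc1cc(OC)cc(-c2nc(Cc3c[nH]c4ccccc34)no2)c1` has not yet been measured; it arises from compound 2 by methoxy in place of hydrogen on an aromatic carbon, the same kind of change, though here the entering group sits meta to a large group rather than para to it. In this assay the step is expected to be a 1.5-fold lower number from compound 2 to compound 4 (0.19 log units; within the scatter), an expectation resting on a 1.9-fold lower number from compound 1 to compound 3 (0.29 log units; within the scatter). Compound 4 is therefore estimated at 12000 nM, with a likely range from 5000 nM to 30000 nM.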

Compound 4, half-maximal inhibitory concentration: > 50000 nM
Compound 4: only a limit was reported; the forecaster's own chance of this, stated with the estimate: 5%; middle value at least 4.1-fold (0.61 log units) from the limit.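

In this assay the methoxy change did not carry over from one core to the other: it gave an at least 2.7-fold higher number from compound 2 to compound 4 (0.43 log units; beyond the scatter), while the earlier step ran in the opposite direction, and the two steps differ: the same change on two cores in this assay, a 1.9-fold lower number (0.29 log units; within the scatter) from compound 1 to compound 3 and an at least 2.7-fold higher number (0.43 log units; beyond the scatter) from compound 2 to compound 4, at least 5.2-fold (0.72 log units) apart, beyond the scatter of two such steps Compound 4 gives > 50000 nM, which is a limit of the assay and not a number: the limit of > 50000 nM in this assay, at which 1 of the 4 values shown sits. The comparison rests on one pair on each core, and it does not show why the two steps differ or how the change would behave on any other core.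

The compounds shown leave open whether a hydroxyl, an amine or a fluorine in the place of this methoxy would follow the same course. They also leave open whether a longer chain such as ethoxy would do so.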